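Pyrimidine in place of pyridine on the vinyl sulfone

This account rests on a few compounds, and the source may have more. Where it says the series, first, only, none or still open, it means among the compounds named here.

Three compounds share one core and differ only in the aromatic ring on the double bond. Compound 1 `COc1cccc(S(=O)(=O)/C=C/c2ccccn2)c1` gives 98.9% in an ADME assay on BV-2 cells (Mus musculus) for cytotoxicity, with a stated time of 24 h, tested at 50 uM (on this read-out lower numbers stand for a stronger effect and higher numbers for a weaker effect at the one concentration tested), and compound 2 `COc1cccc(S(=O)(=O)/C=C/c2cccnc2)c1` gives 90.8%; their step is a number 8.1 percentage points lower from compound 1 to compound 2 (within the scatter). Compound 3 `COc1cccc(S(=O)(=O)/C=C/c2ccncc2)c1` gives 21.3% and stands lowest of the three, as the steps of a number 77.6 percentage points lower from compound 1 to compound 3 (beyond the scatter) and a number 69.5 percentage points lower from compound 2 to compound 3 (beyond the scatter) show.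

Compound 4 `COc1cccc(S(=O)(=O)/C=C/c2cncnc2)c1` is not yet measured. It differs from compound 3 by pyrimidin-5-yl in place of pyridin-4-yl on a double-bonded chain carbon bound to a double-bonded chain carbon. Among the measured compounds shown here, no measured step carries a pyrimidin-5-yl, so the two steps that bear on it are the ones leading into compound 3: both large, both downward, and both tied to the pyridin-4-yl that now leaves. With that group gone, the number for compound 4 is expected to climb back toward the values of compound 1 and compound 2, though how far is open; the step of a number 38.7 percentage points higher from compound 3 to compound 4 (beyond the scatter) is the estimated outcome. Compound 4 is therefore estimated at 60%, within a range from 20% to 95%.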

Compound 4, a percentage reported as activity, at one concentration (the size of the read-out at that concentration, not a potency): 100%
For compound 4 the middle estimate is 40 percentage points below the measured one, outside the stated range (above it).
By their numbers in this assay, from the lowest: compound 3; then compounds 2, 1 and 4 (each within the scatter of the next).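

At the place on a double-bonded chain carbon bound to a double-bonded chain carbon, the low number in this assay does not extend from pyridin-4-yl to pyrimidin-5-yl: the change gives a number 78.7 percentage points higher from compound 3 to compound 4 (beyond the scatter), while the other two comparisons give a number 9.2 percentage points higher from compound 2 to compound 4 (within the scatter) and a number 1.1 percentage points higher from compound 1 to compound 4 (within the scatter). The count of hetero atoms in the ring therefore does not track the read-out across these four compounds, as pyrimidin-5-yl has 2 hetero atoms yet only the pyridin-4-yl of compound 3 stands apart. Nothing available here accounts for that difference.

The compounds shown leave open whether a plain phenyl, or a pyridin-4-yl bearing an amine or a methyl group, would fall with compound 3 or with the other three. They also leave open whether pyridin-4-yl would stand apart as clearly if a hydroxyl replaced the methoxy on the shared core.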